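A few compounds are considered here, and "the series" means these few. Any claim that something is new, unique, unknown or untested is made for them only; others in the source may bear on it.

Of the compounds shown here, three have so far been measured in a functional assay on PC-3 cells (Homo sapiens) for cytotoxicity, read by MTT assay, with a stated time of 48 h; a lower number here means a stronger inhibitor, a higher number a weaker inhibitor. Compound 1, `CC1=NN(C(=O)CN2CCN(C(=O)OC(C)(C)C)CC2)C(c2ccccc2O)C1`, gives 3440 nM. Compound 2, `CC(=O)Oc1ccccc1C1CC(C)=NN1C(=O)CCl`, gives 3580 nM. Compound 3, `O=C(CCl)N1N=C(c2cc3ccccc3oc2=O)CC1c1ccccc1`, gives 2980 nM. Of these three numbers, that of compound 3 is the lowest, but compound 1 and compound 2 both sit within the usual scatter of it, so the three cannot be told apart on what has been measured. Compound 4, `CCNCC(=O)N1N=C(c2cc3ccccc3oc2=O)CC1c1ccccc1`, has not yet been measured. It differs from compound 3 in a single place: ethylamino in place of chloro on a saturated chain carbon bound to a carbonyl carbon. Among the measured compounds shown here, no pair of measured compounds shows this change, so no measured step can guide the expectation, and the three measured compounds fall close together despite differing widely in structure. Compound 4 is expected to give about 5000 nM in this assay, with a range from 1500 nM to 16000 nM. The step from compound 3 to compound 4 is accordingly estimated at a 1.7-fold higher number from compound 3 to compound 4 (0.22 log units; within the scatter), a modest move toward a higher number that may not exceed the scatter.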

Compound 4, half-maximal inhibitory concentration: 5580 nM
Estimate against measurement, compound 4: 1.1-fold (0.05 log units) below; low and high end bracket the measured number.
By their numbers in this assay, from the lowest: compounds 3, 1, 2 and 4 (each within the scatter of the next).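

In this assay, ethylamino in place of chloro on a saturated chain carbon bound to a carbonyl carbon gives a 1.9-fold higher number from compound 3 to compound 4 (0.27 log units; within the scatter). This is the first change in a single place among the compounds shown, and it indicates that at this position chloro can be exchanged for a larger group carrying a hydrogen-bond donor and acceptor without a shift beyond the scatter. Nothing available accounts for the size or direction of this step.

Going by these compounds, whether dimethylamino, a longer chain such as butylamino, or a carboxylic acid at this place would move the number beyond the scatter remains open. Also open, on these data alone, is whether the same exchange of chloro for ethylamino on the core of compound 2 would give a similar step.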